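The compounds below may be only part of what the source reports. "The series", "measured", "known", "first", "only" and "open" are said of these compounds alone.

Measured so far:
compound 1 `O=c1cc(-c2ccccc2)oc2cccc(OCCCN3CCC(O)CC3)c12` — 91 nM
compound 2 `O=c1cc(-c2ccccc2)oc2cccc(OCCCCN3CCC(O)CC3)c12` — 177 nM
compound 3 `O=c1cc(-c2ccccc2)oc2cc(OCCCCCCN3CCC(O)CC3)ccc12` — 70 nM

All three were read in an assay on isolated protein (Cavia porcellus) with Sigma non-opioid intracellular receptor 1 (Homo sapiens) as the target, read by radioligand binding; on this read-out higher numbers stand for weaker inhibition and lower numbers for stronger inhibition. Compound 1 and compound 2 share a core and differ by (4-hydroxypiperidin-1-yl)methyl in place of 4-hydroxypiperidin-1-yl on a saturated chain carbon, three bonds along the chain from an oxygen on an aromatic ring; this gave a 1.9-fold higher number from compound 1 to compound 2 (0.29 log units; within the scatter). Compound 3 carries a different core; the difference between the two cores is not broken down here. In this assay compound 3 gives 70 nM, within the scatter of compound 1 and beyond it against compound 2.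

Compound 4 `O=c1cc(-c2ccccc2)oc2cc(OCCCCCCCN3CCC(O)CC3)ccc12` is not yet measured. It differs from compound 3 by (4-hydroxypiperidin-1-yl)methyl in place of 4-hydroxypiperidin-1-yl on a saturated chain carbon, six bonds along the chain from an oxygen on an aromatic ring. This is the same kind of change as from compound 1 to compound 2, not the same: there the place was three bonds along the chain from an oxygen on an aromatic ring, here it is six bonds along the chain from an oxygen on an aromatic ring, and the cores differ.

The expectation for compound 4 is a step of a 1.6-fold higher number from compound 3 to compound 4 (0.20 log units; within the scatter) in this assay. Among the measured compounds shown here, this rests on compound 1 and compound 2, where the same kind of change gave a 1.9-fold higher number from compound 1 to compound 2 (0.29 log units; within the scatter), with the caveat that only this one pair supports it. For compound 4 the estimated value in this assay is 110 nM, expected to fall between 50 nM and 250 nM.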

Compound 4, half-maximal inhibitory concentration: 19 nM
For compound 4 the middle estimate is 5.8-fold (0.76 log units) above the measured one; measured number below the stated range.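

In this assay, (4-hydroxypiperidin-1-yl)methyl in place of 4-hydroxypiperidin-1-yl, six bonds along the chain from an oxygen on an aromatic ring, gave a 3.7-fold lower number from compound 3 to compound 4 (0.57 log units; beyond the scatter). In this series the change does not carry over from one core to the other as a fixed step: the same change on two cores in this assay, a 1.9-fold higher number (0.29 log units; within the scatter) from compound 1 to compound 2 and a 3.7-fold lower number (0.57 log units; beyond the scatter) from compound 3 to compound 4, 7.2-fold (0.86 log units) apart, beyond the scatter of two such steps

Among the compounds shown here, each core supplies only one pair, and the two pairs differ both in core and in place, three bonds along the chain in one and six in the other, so these data do not show whether the core, the place or the two together set the outcome.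

Still open, on these data alone, is how the core of compound 1 would respond to the chain of compound 4, and how the core of compound 3 would respond to the chain of compound 1. Also open, as far as these compounds go, is whether the lower number from compound 3 to compound 4 would persist with a longer chain or with another amine, such as morpholine, in place of the 4-hydroxypiperidine.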